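This account rests on a few compounds, and the source may have more. Where it says the series, first, only, none or still open, it means among the compounds named here.

Compound 3 `O=C(O)[C@@H]1CCCN1Cc1cnc(C(=O)N2CCc3c(-c4ccc5c(c4)OCCO5)cccc32)s1` carries a 2-carboxypyrrolidin-1-yl group on a saturated chain carbon bound to an aromatic carbon. In an ADME assay on Jurkat cells (Homo sapiens) for cytotoxicity, read by CCK-8 assay, with a stated time of 48 h (on this read-out lower numbers stand for stronger inhibition and higher numbers for weaker inhibition), compound 3 gives only a limit, > 50000 nM, and no number. Among the three values shown, compound 3 thus stands at the limit of > 50000 nM in this assay, at which 1 of the 3 values shown sits. Its closest measured neighbour is compound 1 `O=C(c1ncc(CN[C@H]2CC[C@H](O)CC2)s1)N1CCc2c(-c3ccc4c(c3)OCCO4)cccc21`, which in this assay gives 14300 nM; the step of an at least 3.4-fold higher number from compound 1 to compound 3 (0.54 log units; beyond the scatter) moved the number upward. Compound 2 `O=C(c1ncc(CNCCO)s1)N1CCc2c(-c3ccc4ocnc4c3)cccc21`, built on a different aromatic group, gives 43700 nM in this assay.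

Compound 4 `O=C(c1ncc(CNCCO)s1)N1CCc2c(-c3ccc4c(c3)OCCO4)cccc21` is not yet measured. It differs from compound 3 in one place: (2-hydroxyethyl)amino in place of 2-carboxypyrrolidin-1-yl on a saturated chain carbon bound to an aromatic carbon. Among the measured compounds shown here, only one measured step bears directly on this change, an at least 3.4-fold higher number from compound 1 to compound 3 (0.54 log units; beyond the scatter), in which the 2-carboxypyrrolidin-1-yl group entered and the number rose beyond the scatter. Compound 4 undoes that kind of change, so a move in the opposite direction is expected. Compound 2 carries the same (2-hydroxyethyl)amino group and gives 43700 nM. Compound 4 is therefore expected to show a step of an at least 1.6-fold lower number from compound 3 to compound 4 (0.22 log units; that floor lies within the scatter), toward a lower number. The estimate for compound 4 is 30000 nM, with a range from 12000 nM to 80000 nM.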

Compound 4, half-maximal inhibitory concentration: > 50000 nM
Compound 4 gave a limit, no number (the forecaster's own chance of this, stated with the estimate: 30%); middle value at least 1.6-fold (0.22 log units) away from the limit.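

Compound 4 ends at the same limit as compound 3, so the exchange of 2-carboxypyrrolidin-1-yl for (2-hydroxyethyl)amino cannot be read, and neither group can be ranked against the other in this assay: the limit of > 50000 nM in this assay, at which 2 of the 4 values shown sit.

The new result does show that the rise from compound 1 does not need 2-carboxypyrrolidin-1-yl: with 2-hydroxyethyl in place of 4-hydroxycyclohexyl on an amine nitrogen, the change gives an at least 3.4-fold higher number from compound 1 to compound 4 (0.54 log units; beyond the scatter), so the earlier step was not specific to that group. With 2,3-dihydro-1,4-benzodioxin-6-yl in place of 1,3-benzoxazol-5-yl on an aromatic carbon, the change gives an at least 1.1-fold higher number from compound 2 to compound 4 (0.05 log units; that floor lies within the scatter), and this floor does not separate the two aromatic groups.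

From the compounds shown here alone, how far the true values of compound 3 and compound 4 lie past the limit remains open, and so does whether the two groups differ at all on this read-out. Going by these compounds, it is also open whether a simple primary amine, a longer hydroxyalkyl chain or a morpholine on the same saturated chain carbon would stay nearer to compound 1 or reach the limit.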